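The compounds below may be only part of what the source reports. "The series", "measured", "known", "first", "only" and "open" are said of these compounds alone.

Compound 2 `COc1ccc(-n2cc(CN3C(=O)C[C@@H]4CC[C@@]3(C)C4(C)C)nn2)cc1` gives 70 nM in a functional assay on LoVo cells (Homo sapiens) for inhibition, read by MTT assay, with a stated time of 24 h; on this read-out higher numbers stand for weaker inhibition and lower numbers for stronger inhibition. It sits level with compound 1 `CC1(C)[C@H]2CC[C@]1(C)N(Cc1cn(-c3cccc(Cl)c3)nn1)C(=O)C2`, which gives 70 nM in this assay, and compound 3 `CC1(C)[C@H]2CC[C@]1(C)N(Cc1cn(-c3ccccc3C#N)nn1)C(=O)C2` gives 140 nM, so that a 2.0-fold higher number from compound 2 to compound 3 (0.30 log units; within the scatter) stays inside the usual scatter. Compound 4 `CC1(C)[C@H]2CC[C@]1(C)N(Cc1cn(-c3ccccc3Br)nn1)C(=O)C2` carries 2-bromophenyl in place of 4-methoxyphenyl on an aromatic nitrogen. Among the measured compounds shown here, two measured steps bear on this change: no change at the digits printed from compound 1 to compound 2 (within the scatter) and a 2.0-fold higher number from compound 2 to compound 3 (0.30 log units; within the scatter), each swapping one aryl group for another on the same aromatic nitrogen, and neither moved the number beyond the scatter. The step into compound 4 is therefore expected to be small as well, roughly a 1.4-fold higher number from compound 2 to compound 4 (0.15 log units; within the scatter), with no direction beyond the scatter to call. Compound 4 is estimated to give 100 nM, within a range from 50 nM to 220 nM.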

Compound 4, half-maximal inhibitory concentration: 60 nM
The estimate for compound 4 lay 1.7-fold (0.22 log units) above the measured number; the range from low to high includes it.
By their numbers in this assay, from the lowest: compounds 4, 1, 2 and 3 (each within the scatter of the next, the first and the last beyond it).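

In this assay, 2-bromophenyl behaves like the two aryl groups it was compared with, giving a 1.2-fold lower number from compound 2 to compound 4 (0.07 log units; within the scatter) and a 1.2-fold lower number from compound 1 to compound 4 (0.07 log units; within the scatter) on this aromatic nitrogen. Among the compounds shown here, the first step beyond the scatter at this position comes with a 2.3-fold lower number from compound 3 to compound 4 (0.37 log units; beyond the scatter) for bromo in place of cyano on an aromatic carbon, so the group on this phenyl ring can shift the number, though only modestly. Nothing available explains that shift. Still open, going by these compounds, is whether an amine or a carboxylic acid on this phenyl ring, or a longer chain in its place, would move the number further.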